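Benzyl ether variation on a shared core: second substituent probed

The compounds below may be only part of what the source reports. "The series", "measured", "known", "first", "only" and "open" are said of these compounds alone.

Compound 1 `Cc1nn(-c2ncnc3nc[nH]c23)c2c1C(C(=O)NCc1ccc(F)cc1)CC(=O)N2` in a functional assay on HEK293 cells for agonist activity at G-protein coupled receptor 39 (Homo sapiens), read by scintillation proximity assay and inositol phosphate accumulation, with a stated time of 75 min, in the presence of a further agent that is not named here (on this read-out higher numbers stand for an effect only at larger amounts of compound and lower numbers for an effect already at smaller amounts), gives 4 nM. Compound 2 `Cc1nn(-c2ncnc3nc[nH]c23)c2c1C(OCc1ccc(C#N)cc1)CC(=O)N2`, the ether counterpart, gives 4 nM in this assay, level with compound 1 within the scatter, so the two sit together. For the measured compounds named here, no step between measured compounds is available here. Compound 3 `Cc1nn(-c2ncnc3nc[nH]c23)c2c1C(OCc1ccccc1Cl)CC(=O)N2` departs from compound 2 by 2-chlorophenyl in place of 4-cyanophenyl on a saturated chain carbon bound to an oxygen on a saturated carbon. Going by the values given here, with no comparable step to lean on, the expected step of a 1.5-fold higher number from compound 2 to compound 3 (0.18 log units; within the scatter) is small, in either direction, and no larger than the scatter. Compound 3 is therefore expected to give 6 nM in this assay, within a range of 2 nM to 20 nM.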

Compound 3, half-maximal effective concentration: 2 nM
Beside the measured number, compound 3's estimate is 3.0-fold (0.48 log units) above it; the range from low to high includes it.
By their numbers in this assay, from the lowest: compounds 3, 1 and 2 (each within the scatter of the next).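

In this assay, 2-chlorophenyl in place of 4-cyanophenyl gives a 2.0-fold lower number from compound 2 to compound 3 (0.30 log units; within the scatter). On a saturated chain carbon bound to an oxygen on a saturated carbon, this pair therefore shows that the nitrile, with its hydrogen-bond acceptor, can be exchanged for chlorine without a change beyond the scatter. Nothing on hand gives a reason for this step. Open, going by these compounds, is whether an amine or a carboxylic acid on the aromatic ring keeps values at this level. On these data alone, a longer chain in place of the benzyl group is equally open.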